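A few compounds are considered here, and "the series" means these few. Any claim that something is new, unique, unknown or untested is made for them only; others in the source may bear on it.

Three analogues share one core and differ only in the aryl group on the amide-type nitrogen. Compound 1 `COc1ccc(NC(=O)/C=C/C(=O)N2C/C(=C\c3ccc([N+](=O)[O-])cc3)C(=O)/C(=C/c3ccc([N+](=O)[O-])cc3)C2)cc1` gives 760 nM in a functional assay on CCRF-CEM cells (Homo sapiens) for cytotoxicity; on this read-out higher numbers stand for weaker inhibition and lower numbers for stronger inhibition. Compound 2 `CC(=O)c1ccc(NC(=O)/C=C/C(=O)N2C/C(=C\c3ccc([N+](=O)[O-])cc3)C(=O)/C(=C/c3ccc([N+](=O)[O-])cc3)C2)cc1` gives 360 nM, and compound 3 `Cc1cccc(C)c1NC(=O)/C=C/C(=O)N1C/C(=C\c2ccc([N+](=O)[O-])cc2)C(=O)/C(=C/c2ccc([N+](=O)[O-])cc2)C1` gives 230 nM. Compound 3 thus shows the lowest of the three numbers, though its gap to compound 2 lies within the scatter; only against compound 1 is the step clear, a 3.3-fold lower number from compound 1 to compound 3 (0.52 log units; beyond the scatter). Compound 2 against compound 3 reads a 1.6-fold lower number from compound 2 to compound 3 (0.19 log units; within the scatter), and compound 1 against compound 2 reads a 2.1-fold lower number from compound 1 to compound 2 (0.32 log units; beyond the scatter).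

Compound 4 `Cc1ccc(NC(=O)/C=C/C(=O)N2C/C(=C\c3ccc([N+](=O)[O-])cc3)C(=O)/C(=C/c3ccc([N+](=O)[O-])cc3)C2)cc1` is the next step: 4-methylphenyl in place of 2,6-dimethylphenyl on an amide-type nitrogen. Among the measured compounds shown here, two measured steps bear on this position. The step from compound 1 to compound 3 was modest and beyond the scatter, while the step from compound 2 to compound 3 stayed within it. The group entering in compound 4 resembles those of compounds 1 and 2 more than the one leaving, so a modest rise toward their numbers is expected, a 1.7-fold higher number from compound 3 to compound 4 (0.24 log units; within the scatter), though the change could also fall within the scatter. Compound 4 is therefore estimated at 400 nM in this assay, with a range from 200 nM to 900 nM.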

Compound 4, half-maximal inhibitory concentration: 890 nM
For compound 4 the middle estimate is 2.2-fold (0.35 log units) below the measured one; low and high end bracket the measured number.
By their numbers in this assay, from the lowest: compounds 3 and 2 (each within the scatter of the next); then compounds 1 and 4 (each within the scatter of the next).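

In this assay the 4-methylphenyl group does not behave like the 2,6-dimethylphenyl group, a 3.9-fold higher number from compound 3 to compound 4 (0.59 log units; beyond the scatter), so these two methyl-bearing aryl groups on the amide-type nitrogen are not interchangeable. The group on the aromatic carbon now separates only part of the series: methyl in place of acetyl gives a 2.5-fold higher number from compound 2 to compound 4 (0.39 log units; beyond the scatter), while methyl in place of methoxy gives a 1.2-fold higher number from compound 1 to compound 4 (0.07 log units; within the scatter), a step that stays within the scatter. Compound 4 therefore falls with compound 1 and apart from both compound 2 and compound 3, so the two lower numbers in this series belong to the 4-acetylphenyl and 2,6-dimethylphenyl groups alone.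

As far as these compounds go, whether an unsubstituted phenyl, or an amine or a carboxylic acid on the aromatic carbon that carries the methyl of compound 4, would fall with compound 1 and compound 4 or with compound 2 and compound 3 stays open. Nothing available here accounts for the differences between these compounds.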